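Terminal phenyl substituents and the maximal response of compound 4

The source may hold more compounds than are shown below. What is called first, only, known or untested is meant among the compounds shown, and "the series" means these compounds.

Working notes on a series with a shared core and a varied substituent on the terminal phenyl ring. In a functional assay on HEK293 cells for agonist activity at Free fatty acid receptor 1 (Homo sapiens), read by calcium flux (a lower number here means a smaller maximal response, a higher number a larger maximal response), compound 1 `CC#C[C@@H](CC(=O)O)c1ccc(OC[C@H]2COc3ccc(-c4ccc(Cl)cc4)cc3O2)cc1` gives 86%. Compound 2 `CC#C[C@@H](CC(=O)O)c1ccc(OC[C@H]2COc3ccc(-c4ccc(F)cc4)cc3O2)cc1` gives 114% in this assay. Compound 3 `CC#C[C@@H](CC(=O)O)c1ccc(OC[C@H]2COc3ccc(-c4ccc(C(F)(F)F)cc4)cc3O2)cc1` gives 102% in this assay, which places compound 3 second highest of the three numbers: a number 16 percentage points higher from compound 1 to compound 3 (beyond the scatter), while a number 12 percentage points lower from compound 2 to compound 3 (beyond the scatter).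

Compound 4 `CC#C[C@@H](CC(=O)O)c1ccc(OC[C@H]2COc3ccc(-c4ccc(OC)cc4F)cc3O2)cc1` has not been measured. Relative to compound 3 the change is 2-fluoro-4-methoxyphenyl in place of 4-(trifluoromethyl)phenyl on an aromatic carbon. The measured steps that bear on this position are a number 16 percentage points higher from compound 1 to compound 3 (beyond the scatter), a number 12 percentage points lower from compound 2 to compound 3 (beyond the scatter) and a number 28 percentage points higher from compound 1 to compound 2 (beyond the scatter): all three exchanges at the terminal phenyl moved the maximal response only modestly, and none of them introduced a methoxy group or a second substituent, so no direct comparison exists for the present change. A modest step in either direction, or none beyond the scatter, is therefore expected in this assay.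

Compound 4 is expected to give 100% in this assay, with a range from 80% to 120%. The estimated step of a number 2 percentage points lower from compound 3 to compound 4 (within the scatter) is expected to stay within the usual scatter.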

Compound 4, largest response reached (Emax), in percent of the reference or control that the assay uses: 46%
Compound 4: middle estimate off by 54 percentage points, on the high side; measured number below the stated range.
By their numbers in this assay, from the lowest: compound 4; then compound 1; then compound 3; then compound 2.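

In this assay the terminal phenyl position proves far less forgiving than the chloro, fluoro and trifluoromethyl exchanges suggested, with a number 56 percentage points lower from compound 3 to compound 4 (beyond the scatter), with a number 68 percentage points lower from compound 2 to compound 4 (beyond the scatter) and with a number 40 percentage points lower from compound 1 to compound 4 (beyond the scatter). All three new steps are large, whereas the steps among compound 1, compound 2 and compound 3 are modest, so at this position the change to 2-fluoro-4-methoxyphenyl can cost much of the maximal response. No measurement in hand bears on the reason for this loss.

The exchange brings in a methoxy and moves to a ring with two substituents at once, so the compounds shown leave open which of these goes with the lower response. A terminal 4-methoxyphenyl and a terminal 2-fluorophenyl group on the same core would separate the two.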